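The source may report more compounds than this note shows. Statements on the series, on what has been measured and on what is new or still open speak of the compounds shown alone.

Of the compounds shown here, two of a shared core have been measured in an ADME assay on HEp-2 cells (Homo sapiens) for cytotoxicity, with a stated time of 5 days; a lower number here means that less compound is tolerated, a higher number that more compound is tolerated. Compound 1, `Nc1ncnn2c([C@@H]3O[C@H](CO)[C@@H](O)[C@H]3O)ccc12`, gives 38 nM. Compound 2, `C[C@@]1(c2ccc3c(N)ncnn23)O[C@H](CO)[C@@H](O)[C@H]1O`, gives 93000 nM, the highest of the two numbers and far beyond the scatter from compound 1. Compound 3, `C#C[C@@]1(c2ccc3c(N)ncnn23)O[C@H](CO)[C@@H](O)[C@H]1O`, carries ethynyl in place of methyl on a saturated ring carbon. For the measured compounds named here, with no measured pair of this kind to lean on, a moderate downward step is expected a 4.7-fold lower number from compound 2 to compound 3 (0.67 log units; beyond the scatter), carrying only part of the way back toward compound 1. Compound 3 is therefore expected near 20000 nM, within roughly 2000 nM to 100000 nM.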

Compound 3, half-maximal cytotoxic concentration: > 200000 nM
Compound 3 ended at the assay's limit; the forecaster's own chance of this, stated with the estimate: 25%; at least 10-fold (1.00 log units) between middle value and limit.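

For compound 3, the value > 200000 nM is a limit of the assay and not a number. Ethynyl in place of methyl on this saturated ring carbon gives an at least 2.1-fold higher number from compound 2 to compound 3 (0.33 log units; beyond the scatter) and so shows that the change moves toward more compound being tolerated, not less. The full size of that step cannot be read, as the value sits at the end of the measurable range: the limit of > 200000 nM in this assay, at which 1 of the 3 values shown sits.

As far as these compounds go, whether an amine or an ethyl group on this carbon would follow methyl or ethynyl stays open. From the compounds shown here alone, the true number for compound 3 also stays open.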